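This account rests on a few compounds, and the source may have more. Where it says the series, first, only, none or still open, it means among the compounds named here.

Measured compounds:
- Compound 1 `COc1c(OCCCCN2CCN(C)CC2)cc(O)c2c(=O)cc(-c3ccc(Cl)cc3)oc12` gives 1430 nM in a functional assay on A549 cells (Homo sapiens) for cytotoxicity, read by MTT assay, with a stated time of 72 h; a lower number here means a stronger inhibitor, a higher number a weaker inhibitor.
- Compound 2 `COc1c(OCCCCN2CCN(C)CC2)cc(O)c2c(=O)cc(-c3ccc(F)cc3)oc12` gives 2220 nM in this assay.
- Compound 3 `CCN(CC)CCCOc1c(OCc2ccccc2)cc(O)c2c(=O)cc(-c3ccccc3)oc12` gives 3620 nM in this assay.

Compound 3 carries the highest number of the three in this assay; its gap to compound 2 lies within the scatter, while its gap to compound 1 lies beyond it. Going by the values given here, the only step with a single change is a 1.6-fold higher number from compound 1 to compound 2 (0.19 log units; within the scatter), which concerns a halogen on an aromatic ring and does not bear on the change examined here.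

Compound 4 `CN1CCN(CCCCOc2c(OCc3ccccc3)cc(O)c3c(=O)cc(-c4ccccc4)oc23)CC1` differs from compound 3 in the amine at the end of the chain: (4-methylpiperazin-1-yl)methyl in place of diethylamino on a saturated chain carbon, three bonds along the chain from an oxygen on an aromatic ring. Among the compounds with values here, no measured pair isolates this exchange. Compounds 1 and 2, which carry the entering group on a related core, sit at numbers comparable to or somewhat lower than compound 3, so a small step is expected, if any, a 1.4-fold lower number from compound 3 to compound 4 (0.16 log units; within the scatter). Compound 4 is therefore estimated at 2500 nM, with a range from 1000 nM to 6000 nM.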

Compound 4, half-maximal inhibitory concentration: 2910 nM
Compound 4: the middle estimate sits 1.2-fold (0.07 log units) below what was measured, and the stated range covers the measured number.
By their numbers in this assay, from the lowest: compounds 1, 2, 4 and 3 (each within the scatter of the next, the first and the last beyond it).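

The step of a 1.2-fold lower number from compound 3 to compound 4 (0.09 log units; within the scatter) in this assay lies within the scatter, so the two compounds cannot be told apart in this assay. Going by these compounds alone, this is the first reading of a change on the saturated chain rather than on the halogen of the aromatic ring: the open diethylamino end gives way to a six-membered ring with 2 hetero atoms, and the measured number stays within the scatter. Nothing available explains why the two amines read alike.

Read one bond further out, the change is 3-(diethylamino)propyl to 4-(4-methylpiperazin-1-yl)butyl, so the amine and the chain length change together, and the pair cannot separate them. A 4-(diethylamino)butyl group would isolate the chain length, while a morpholine at the end of the chain would test a different ring amine.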